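A few compounds are considered here, and "the series" means these few. Any claim that something is new, unique, unknown or untested is made for them only; others in the source may bear on it.

Of the compounds shown here, three have been measured in a functional assay on PBMC cells (Homo sapiens) for inhibition; a lower number here means a stronger inhibitor, a higher number a weaker inhibitor. Compound 1 `C[C@H](N)C(=O)NS(=O)(=O)OC[C@H]1OC[C@@H](n2cnc3c(N)ncnc32)[C@H](O)[C@@H]1O` gives 300 nM. Compound 2 `CCC[C@H](N)C(=O)NS(=O)(=O)OC[C@H]1O[C@@H](n2cnc3c(N)ncnc32)[C@H](O)[C@@H]1O` gives 4700 nM, the second highest of the three numbers. Compound 3 `CSCC[C@H](N)C(=O)NS(=O)(=O)OC[C@H]1OC[C@@H](n2cnc3c(N)ncnc32)C[C@@H]1O` gives 5500 nM, which lies within the usual scatter of the value of compound 2, so the two cannot be told apart. Compound 1 sits far lower, beyond the scatter, but it differs from compound 2 in more than one place, so nothing can be read from that gap about a single change.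

The next compound, compound 4 `CC(C)C[C@H](N)C(=O)NS(=O)(=O)OC[C@H]1O[C@@H](n2cnc3c(N)ncnc32)[C@H](O)[C@@H]1O`, departs from compound 2 in one place only: methyl in place of hydrogen on a saturated chain carbon bound to two saturated chain carbons. Among the compounds with values here, no pair among the measured compounds shows what this change does, so there is no measured step to lean on.

The step is expected to be small, an estimated 1.6-fold lower number from compound 2 to compound 4 (0.19 log units; within the scatter), not clearly beyond the scatter. On that basis compound 4 is expected to give about 3000 nM in this assay, within a range from 600 nM to 15000 nM.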

Compound 4, half-maximal inhibitory concentration: 1100 nM
Estimate against measurement, compound 4: 2.7-fold (0.44 log units) above; the measured number falls inside the stated range.
By their numbers in this assay, from the lowest: compound 1; then compound 4; then compounds 2 and 3 (each within the scatter of the next).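

In this assay, methyl in place of hydrogen on a saturated chain carbon bound to two saturated chain carbons, which turns propyl into isobutyl, gives a 4.3-fold lower number from compound 2 to compound 4 (0.63 log units; beyond the scatter) and so moves the number beyond the scatter. Within the data shown here, this is the first single change that can be read here, since the earlier compounds differ from each other in more than one place, and it shows that this chain carbon does respond to one added methyl. Nothing measured here accounts for the size of this step.

Among these compounds, with only one step at this position, it remains open whether a longer chain, a hydroxyl or an amine on the same carbon would shift the number in the same direction. From the compounds shown here alone, it also remains open whether the same methyl step would hold on the core of compound 1 or of compound 3.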